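From a Chain to a Ring on One Aromatic Carbon

The compounds below may be only part of what the source reports. "The series", "measured", "known", "first", "only" and "open" are said of these compounds alone.

Of the compounds shown here, three have been measured in an assay on cells for inhibition of cytochrome P450 11B2, mitochondrial (Homo sapiens), read by HTRF; a lower number here means a stronger inhibitor, a higher number a weaker inhibitor. Compound 1 `C[C@@H](NS(C)(=O)=O)c1cncc(N2C(=O)c3ccc(Cl)cc3C2(C)C)c1` gives 8 nM. Compound 2 `CC[C@@H]1c2cc(Cl)ccc2C(=O)N1c1cncc2c1CCC[C@H]2NC(C)=O` gives 7 nM, and compound 3 `O=C(Nc1cccnc1)c1ccc(Cl)cc1` gives 420 nM. On these numbers compound 1 stands second highest of the three: compound 2 lies within the usual scatter of it, so the two cannot be placed in any order, while compound 3 lies far beyond the scatter on the weaker side.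

Compound 4 `CC(=O)N1CC[C@@H](Oc2cncc(N3C(=O)c4ccc(Cl)cc4C3(C)C)c2)C1` has not yet been measured. It differs from compound 1 in a single place: a group of 9 heavy atoms (6 carbon, 1 nitrogen, 2 oxygen; one five-membered non-aromatic ring with 1 hetero atom) in place of a group of 7 heavy atoms (3 carbon, 1 nitrogen, 2 oxygen, 1 sulfur; no ring), on an aromatic carbon The group that leaves has one hydrogen-bond donor and no ring; the group that enters has no hydrogen-bond donor and one five-membered non-aromatic ring with one hetero atom. Both sit on the same aromatic carbon, two atoms from the ring nitrogen, meta to a large group.

For the measured compounds named here, no measured pair differing in one place is available, so the size of this step cannot be read from any measured example. Because compound 1 gives 8 nM and the shared core is unchanged, the step from compound 1 to compound 4 a 1.9-fold higher number from compound 1 to compound 4 (0.27 log units; within the scatter) is expected to be modest, toward a somewhat higher number, and it may well fall within the scatter. Compound 4 is therefore estimated at 15 nM, with a range from 4 nM to 60 nM.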

Compound 4, half-maximal inhibitory concentration: 11 nM
Estimate against measurement, compound 4: 1.4-fold (0.13 log units) above, and the stated range covers the measured number.
By their numbers in this assay, from the lowest: compounds 2, 1 and 4 (each within the scatter of the next); then compound 3.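

In this assay, the step is a 1.4-fold higher number from compound 1 to compound 4 (0.14 log units; within the scatter), which lies within the scatter, so compound 1 and compound 4 cannot be placed in any order. This aromatic carbon, two atoms from the ring nitrogen, can therefore carry two quite different groups without a readable difference in the number: an open chain containing sulfur and a larger group with one five-membered non-aromatic ring. The group that leaves has 1 hydrogen-bond donor and the group that enters has 0 hydrogen-bond donors, so in this pair the donor is not needed to keep the number in the same range.

Because the ring, the donor and the overall size all change in this single step, the compounds shown cannot separate what each contributes, or show whether the defined stereocentre in either group matters. They also leave open how far this tolerance extends, for example to a free amine, a carboxylic acid or a simple hydrogen on the same carbon. No measurement shown here explains why the two groups give such similar numbers.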